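Solubility of a methylcarbamoyl analogue estimated from three measured compounds

The compounds below may be only part of what the source reports. "The series", "measured", "known", "first", "only" and "open" are said of these compounds alone.

Measured compounds in a physicochemical assay for solubility, read by HPLC, in phosphate buffer, with a stated time of 4 h, at pH 7.4; a lower number here means a less soluble compound, a higher number a more soluble compound:
Compound 1 `COCCOC(=O)c1cc(N)c(Nc2ccc(C#N)cc2)cc1Oc1c(C)cc(/C=C/C#N)cc1C` gives 0.77 ug/mL
Compound 2 `CCNC(=O)c1cc(N)c(Nc2ccc(C#N)cc2)cc1Oc1c(C)cc(/C=C/C#N)cc1C` gives 1.08 ug/mL
Compound 3 `Cc1cc(/C=C/C#N)cc(C)c1Oc1cc(Nc2ccc(C#N)cc2)c(N)cc1C(=O)OCCC#N` gives 0.36 ug/mL

Compound 3 stands lowest of the three numbers in this assay; its nearest neighbour is compound 1 and its furthest is compound 2, and both gaps are beyond the scatter. Compound 4 `CNC(=O)c1cc(N)c(Nc2ccc(C#N)cc2)cc1Oc1c(C)cc(/C=C/C#N)cc1C` has not yet been measured. It differs from compound 3 in one place: methylamino in place of 2-cyanoethoxy on a carbonyl carbon.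

Of the measured steps, the closest in kind is a 3.0-fold lower number from compound 2 to compound 3 (0.48 log units; beyond the scatter), which runs the opposite way and swaps an alkylamino group for the 2-cyanoethoxy group. Also relevant are a 2.1-fold lower number from compound 1 to compound 3 (0.33 log units; beyond the scatter) and a 1.4-fold higher number from compound 1 to compound 2 (0.15 log units; within the scatter), the latter showing that an ethylamino group and a 2-methoxyethoxy group gave numbers within the scatter of each other. The step from compound 3 to compound 4 is therefore expected to go upward in this assay by about the reverse of the modest step seen from compound 2 to compound 3, that is a 3.1-fold higher number from compound 3 to compound 4 (0.49 log units; beyond the scatter). Compound 4 is accordingly estimated at 1.1 ug/mL, with a plausible range from 0.5 ug/mL to 2.5 ug/mL, resting on the value of compound 2 1.08 ug/mL as the nearest measured amide.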

Compound 4, solubility: 8.28 ug/mL
For compound 4 the middle estimate is 7.5-fold (0.88 log units) below the measured one, and the stated range ends below it.
By their numbers in this assay, from the lowest: compound 3; then compounds 1 and 2 (each within the scatter of the next); then compound 4.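

In this assay the group on the carbonyl carbon proves able to move the number much further than the earlier compounds showed: methylamino in place of 2-cyanoethoxy gives the largest step among these compounds (a 23-fold higher number from compound 3 to compound 4 (1.36 log units; beyond the scatter)), and methylamino in place of 2-methoxyethoxy is also a large one (an 11-fold higher number from compound 1 to compound 4 (1.03 log units; beyond the scatter)). The amides do not behave as a single class, as shortening ethylamino to methylamino, hydrogen in place of methyl on the chain, gives a clear step (a 7.7-fold higher number from compound 2 to compound 4 (0.88 log units; beyond the scatter)), whereas ethylamino and 2-methoxyethoxy had stood within the scatter of each other, so an amide-type nitrogen on the carbonyl carbon does not by itself set the number here. No measurement is available that bears on why compound 4 stands apart from the other three.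

As far as these compounds go, what a primary carboxamide, a dimethylamino group or a carboxylic acid would give on this carbonyl carbon remains open. From the compounds shown here alone, it also remains open whether the step from ethylamino to methylamino would recur on any core other than the shared one.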